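A few compounds are considered here, and "the series" means these few. Any claim that something is new, unique, unknown or untested is made for them only; others in the source may bear on it.

Working notes on the hydrazone series. Compound 1 `CCOc1cccc(/C=N/NC(=O)c2cnccn2)c1` gives 74% in an ADME assay on J774 cells (Mus musculus) for cytotoxicity, read by MTT assay, with a stated time of 48 h, tested at 50 ug/mL; on this read-out higher numbers stand for a weaker effect at the one concentration tested and lower numbers for a stronger effect. Compound 3 `O=C(N/N=C/c1cccc(O)c1)c1cnccn1` gives 100% in this assay, so a number 26 percentage points higher from compound 1 to compound 3 (beyond the scatter) for the change (hydrogen in place of ethyl on an oxygen on an aromatic ring). Compound 2 `CCOc1ccc(/C=N/NC(=O)c2cnccn2)cc1` gives 100% in this assay; its core and that of compound 1 hold the same atoms joined differently, and the difference between the two cores is not broken down here. Compound 2 and compound 3 sit level within the scatter. Compound 4 `O=C(N/N=C/c1ccc(O)cc1)c1cnccn1` is not yet measured in this assay; it arises from compound 2 by hydrogen in place of ethyl on an oxygen on an aromatic ring, the same change as from compound 1 to compound 3. Because compound 2 already gives 100%, at the top of the scale, the expected step of no change at the digits printed from compound 2 to compound 4 (within the scatter) is far smaller than the earlier one. Compound 4 is expected to give 100%, between 88% and 106%.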

Compound 4, a percentage reported as activity, at one concentration (the size of the read-out at that concentration, not a potency): 100%
Compound 4: middle estimate and measured number agree at the digits printed; measured number inside the range.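

In this assay, the change from ethoxy to hydroxy gives no change at the digits printed from compound 2 to compound 4 (within the scatter). The size of the step therefore does not carry from one core to the other in this series: the same change on two cores in this assay, a number 26 percentage points higher (beyond the scatter) from compound 1 to compound 3 and no change at the digits printed (within the scatter) from compound 2 to compound 4, 26 percentage points apart, beyond the scatter of two such steps. This rests on two cores only, and with compound 2 at 100%, the top of the scale, it does not show what sets the two steps apart or how the change would behave on any further core.

The compounds shown leave open how an amine or a carboxylic acid would read in place of the ethoxy or hydroxy group. They also leave open whether a longer chain on the oxygen would read as ethyl does on each core.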